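Swapping the aryl group on the oxygen of compound 1

The compounds below may be only part of what the source reports. "The series", "measured", "known", "first", "only" and "open" are said of these compounds alone.

- Compound 1 `COc1ccccc1OCC(O)CNCC(=O)Nc1ccc(C2=NNC(=O)CC2)cc1`: 4.6 umol/kg
- Compound 2 `COc1ccccc1OCC(O)CNCC(=O)Nc1ccc(C2=NNC(=O)CC2C)cc1`: 3 umol/kg

Among the measured compounds shown here, in a functional assay on the whole organism with Rattus norvegicus as the target (a higher number here means that more compound is needed for the effect, a lower number that less compound is needed), the only measured step is a 1.5-fold lower number from compound 1 to compound 2 (0.19 log units; within the scatter), so compound 1 stands level with its one neighbour. Compound 3 `O=C1CCC(c2ccc(NC(=O)CNCC(O)COc3cccc4ccccc34)cc2)=NN1` makes a different change, naphthalen-1-yl in place of 2-methoxyphenyl on an oxygen on a saturated carbon. The measured step, methyl in place of hydrogen on a saturated ring carbon, lies elsewhere and offers only weak guidance. No clear shift in either direction is therefore expected, although uncertainty remains wide. The expected step is a 1.2-fold lower number from compound 1 to compound 3 (0.06 log units; within the scatter). The estimate for compound 3 is 4 umol/kg, with an expected range from 1 umol/kg to 16 umol/kg.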

Compound 3, dose for half-maximal effect: 1.4 umol/kg
Compound 3: middle estimate off by 2.9-fold (0.46 log units), on the high side; measured number inside the range.
By their numbers in this assay, from the lowest: compound 3; then compounds 2 and 1 (each within the scatter of the next).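

In this assay, the aryl group on this oxygen proves able to change the dose needed (a 3.3-fold lower number from compound 1 to compound 3 (0.52 log units; beyond the scatter)), which the methyl step on the saturated ring carbon did not show. The change swaps one six-membered aromatic ring and its methoxy oxygen for two aromatic rings of carbon only, and this single pair cannot separate those differences. Nothing at hand explains the shift. A plain phenyl or naphthalen-2-yl group on the same oxygen would help separate them. As far as these compounds go, whether naphthalen-1-yl and the ring methyl work together also stays open.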